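Swapping the aryl on the triazole of compound 1

This account rests on a few compounds, and the source may have more. Where it says the series, first, only, none or still open, it means among the compounds named here.

Of the compounds shown here, three have been measured in a functional assay on PC-3 cells (Homo sapiens) for inhibition, read by sulforhodamine B assay, with a stated time of 48 h, tested at 50 uM; on this read-out lower numbers stand for less inhibition of growth and higher numbers for more inhibition of growth at the one concentration tested. Compound 1 `COc1ccc([C@@H]2C/C(=N/OCc3cn(-c4ccccc4CO)nn3)c3cc(CC=C(C)C)c(OC)cc3O2)cc1` gives 100%, the highest of the three. For the measured compounds named here, compound 2 `COc1cc2c(cc1CC=C(C)C)C(=O)C[C@@H](c1ccc(Oc3ccccc3)cc1)O2` gives 53%, and compound 3 `COc1cc2c(cc1CC=C(C)C)C(=O)C[C@@H](c1ccc(Oc3ccc(Br)cc3)cc1)O2` gives 55%; the only single-point step, a number 2 percentage points higher from compound 2 to compound 3 (within the scatter), stays within the scatter. Compound 4 `COc1ccc([C@@H]2C/C(=N/OCc3cn(-c4ccc(C(N)=O)cc4)nn3)c3cc(CC=C(C)C)c(OC)cc3O2)cc1` differs from compound 1 by 4-carbamoylphenyl in place of 2-(hydroxymethyl)phenyl on an aromatic nitrogen. Going by the values given here, no measured step touches this part of the molecule, and the one step on hand concerns a different core, so it gives no direct guidance on size or direction. Because compound 1 already shows 100%, compound 4 is expected to stay near that level, a change of a number 10 percentage points lower from compound 1 to compound 4 (within the scatter), with an estimated value of 90%, between 65% and 100%.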

Compound 4, percent growth inhibition at one concentration: 100%
Estimate against measurement, compound 4: 10 percentage points below; measured number inside the range.
By their numbers in this assay, from the lowest: compounds 2 and 3 (each within the scatter of the next); then compounds 1 and 4 (each within the scatter of the next).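

In this assay, 4-carbamoylphenyl in place of 2-(hydroxymethyl)phenyl on the aromatic nitrogen gives no change at the digits printed from compound 1 to compound 4 (within the scatter). This position therefore tolerates a change in the substituent on the phenyl ring, and compound 4 holds 100%. Nothing available explains why the two groups read alike.

With a single concentration and both compounds at the top of the read-out, any difference between them stays hidden. As far as these compounds go, it also remains open whether a phenyl ring carrying an amine or a carboxylic acid, or a longer chain on that nitrogen, would hold this level.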